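A few compounds are considered here, and "the series" means these few. Any claim that something is new, unique, unknown or untested is made for them only; others in the source may bear on it.

Measured so far:
compound 1 `CC1=C(C(=O)OC(C)(C)C)C(c2ccoc2)NC(=O)N1` — an assay on membranes from CHO cells for displacement of a labelled ligand from adenosine receptor A1 (Homo sapiens), read by scintillation counting, with a stated time of 60 min, tested at 1 uM; a lower number here means less inhibition, a higher number more inhibition at the concentration tested (going by the name of the read-out): 11%
compound 2 `CCNC(=O)C1=C(C)NC(=O)NC1c1ccoc1` — 1%

Among the compounds with values here, compound 2 carries the lower of the two numbers recorded, and the only neighbour is compound 1; the single measured step, a number 10 percentage points lower from compound 1 to compound 2 (within the scatter), lies within the scatter, so the two compounds cannot be ranked against each other. Within the data shown here, that step replaces tert-butoxy with ethylamino on a carbonyl carbon and is the only information so far on how changes at the carbonyl substituent register in this assay.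

Compound 3 `CC1=C(C(=O)NC(C)C)C(c2ccoc2)NC(=O)N1` differs from compound 2 by methyl in place of hydrogen on a saturated chain carbon bound to an amide-type nitrogen and a saturated chain carbon. Among the measured compounds shown here, no measured step touches this carbon: the recorded step concerns the exchange of the whole ester for an amide, not growth of the alkyl on the amide nitrogen. Given that the one step seen is within the scatter and that both measured numbers are low, nothing in the data points to a shift beyond the scatter for compound 3. The expected step from compound 2 is therefore a number 3 percentage points higher from compound 2 to compound 3 (within the scatter). Compound 3 is estimated at 4%, with a range from -8% to 18%.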

Compound 3, a percentage reported as inhibition, at one concentration (the size of the read-out at that concentration, not a potency): 1%
Estimate against measurement, compound 3: 3 percentage points above; low and high end bracket the measured number.
By their numbers in this assay, from the lowest: compounds 2, 3 and 1 (each within the scatter of the next).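

In this assay, within the data shown here, methyl in place of hydrogen on a saturated chain carbon bound to an amide-type nitrogen and a saturated chain carbon, the change from ethylamino to isopropylamino, gives no change at the digits printed from compound 2 to compound 3 (within the scatter); this is the first reading on the alkyl group of the amide itself, and this one added methyl does not register at the concentration tested. The second ester-to-amide comparison, which sets the isopropyl amide against the tert-butyl ester, gives a number 10 percentage points lower from compound 1 to compound 3 (within the scatter), so two different amides now stand against the tert-butyl ester, and in both cases the step is within the scatter. No measurement is available that bears on the reason for these readings.

Going by these compounds, it remains open whether a longer chain such as n-butyl, or a benzyl group, in place of isopropyl would give a step beyond the scatter in this assay. A carboxylic acid in place of the ester or amide on the carbonyl carbon is equally unresolved, as is any group other than those shown on the rest of the shared core.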